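The source may hold more compounds than are shown below. What is called first, only, known or untested is meant among the compounds shown, and "the series" means these compounds.

Going by the values given here, in an ADME assay on Vero cells (Chlorocebus sabaeus) for cytotoxicity, read by MTT assay, with a stated time of 72 h (on this read-out lower numbers stand for higher toxicity in this test and higher numbers for lower toxicity in this test), two compounds have numbers so far. Compound 1 (`COc1ccc([C@H](O)COC(=O)/C=C/c2ccccc2)cc1OC`) stands at 24300 nM and compound 2 (`COc1ccc([C@H](O)COC(=O)/C=C/c2ccccc2)cc1`) at 33500 nM on that scale, so compound 2 lies within the scatter of compound 1 and the pair cannot be ranked. Compound 3 (`Cc1ccc([C@H](O)COC(=O)/C=C/c2ccccc2)cc1`) differs from compound 2 by methyl in place of methoxy on an aromatic carbon, para to a large group (methyl in place of methoxy on an aromatic carbon). Among the compounds with values here, only one measured step bears on this. Hydrogen in place of methoxy on an aromatic carbon, at another methoxy, gives a 1.4-fold higher number from compound 1 to compound 2 (0.14 log units; within the scatter) and so no step beyond the scatter is expected in this assay in either direction. Within the data shown here, no measured step brings in methyl, which leaves the expectation on thin ground. The estimated step is small (a 1.0-fold lower number from compound 2 to compound 3 (0.02 log units; within the scatter)). Compound 3 is estimated at 32000 nM with an expected range from 16000 nM to 62000 nM on present data.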

Compound 3, half-maximal cytotoxic concentration: > 200000 nM
Compound 3 was reported as a limit; the forecaster's own chance of this, stated with the estimate: 3%; middle value at least 6.2-fold (0.79 log units) away from the limit.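

In this assay, going by these compounds alone, the change at this position, on an aromatic carbon para to a large group, gives an at least 5.9-fold higher number from compound 2 to compound 3 (0.77 log units; beyond the scatter), the first step beyond the scatter. The other methoxy change, a 1.4-fold higher number from compound 1 to compound 2 (0.14 log units; within the scatter), stays within the scatter, so the shown methoxy changes differ in outcome, though they differ both in place and in the group that enters. Compound 3 is reported as a limit and not a number: the limit of > 200000 nM in this assay, at which 1 of the 3 values shown sits.

Still open, as far as these compounds go, is whether the step follows from methoxy leaving or from methyl entering, and how far it extends past the limit. Also open, from the compounds shown here alone, is how an amine, a chlorine atom or a longer chain at this position would read in this assay.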